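The compounds below may be only part of what the source reports. "The series", "measured", "known", "first", "only" and "open" are said of these compounds alone.

Three compounds that share one core were tested in an ADME assay on Huh-7 cells (Homo sapiens) for cytotoxicity, read by MTT assay, with a stated time of 72 h; on this read-out lower numbers stand for higher toxicity in this test and higher numbers for lower toxicity in this test. Compound 1 `COc1cc(OC)c2c(=O)cc(-c3ccc(OCc4cn(-c5ccc(F)cc5F)nn4)c(OC)c3)oc2c1` carries a 2,4-difluorophenyl on an aromatic nitrogen, and in this assay compound 1 reaches only the limit of > 100 ug/mL, a boundary of the test rather than a number. Compound 2 `COc1cc(OC)c2c(=O)cc(-c3ccc(OCc4cn(-c5ccc(Cl)cc5)nn4)c(OC)c3)oc2c1` likewise gives only the limit of > 100 ug/mL. Compound 3 `COc1cc(OC)c2c(=O)cc(-c3ccc(OCc4cn(-c5ccc(F)c(Cl)c5)nn4)c(OC)c3)oc2c1` also stops at the limit of > 100 ug/mL. Because all three sit at the limit of > 100 ug/mL in this assay, at which 3 of the 3 values shown sit, the steps between them cannot be read: a step that the two limits leave unreadable from compound 1 to compound 2, a step that the two limits leave unreadable from compound 1 to compound 3 and a step that the two limits leave unreadable from compound 2 to compound 3 all remain of unknown size. Compound 2 therefore stands at the limit, with nothing to set it apart from its two neighbours. Compound 4 `COc1cc(OC)c2c(=O)cc(-c3ccc(OCc4cn(-c5ccc(Cl)cc5)nn4)c(OCc4cn(-c5ccc(Cl)cc5)nn4)c3)oc2c1` differs from compound 2 by 1-(4-chlorophenyl)-1H-1,2,3-triazol-4-yl in place of hydrogen on a saturated chain carbon bound to an oxygen on an aromatic ring. For the measured compounds named here, no measured step bearing on this change has a readable size, so there is no basis for expecting a move beyond the scatter. Compound 4 is expected to give about 100 ug/mL, between 40 ug/mL and 250 ug/mL. The expected step is a number no higher from compound 2 to compound 4 (the limit leaves the size open).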

Compound 4, half-maximal cytotoxic concentration: > 100 ug/mL
Compound 4 gave a limit, no number; the forecaster's own chance of this, stated with the estimate: 65%; the middle value lies on the limit itself.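

No new step can be read: compound 2 and compound 4 both give a limit rather than a number, because each stops at the same boundary: the limit of > 100 ug/mL in this assay, at which 4 of the 4 values shown sit.

The compounds shown leave open what concentration, if any, would harm the cells in this assay.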